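The source may hold more compounds than are shown below. What is called first, only, known or untested is meant among the compounds shown, and "the series" means these compounds.

Compound 1 `O=C(O)CCCO/N=c1/ccn([C@@H]2O[C@H](COP(=O)(O)OP(=O)(O)OP(=O)(O)O)[C@@H](O)[C@H]2O)c(=O)[nH]1` gives 697 nM in a functional assay on 1321-N1 cells for agonist activity at P2Y purinoceptor 6 (Homo sapiens), read by scintillation counting and inositol phosphate accumulation; on this read-out lower numbers stand for an effect already at smaller amounts and higher numbers for an effect only at larger amounts of compound. Among the measured compounds shown here, compound 2 `COc1ccc(CCCO/N=c2/ccn([C@@H]3O[C@H](COP(=O)(O)OP(=O)(O)OP(=O)(O)O)[C@@H](O)[C@H]3O)c(=O)[nH]2)cc1` gives 277 nM in this assay and so holds the lower of the two numbers measured so far; the step of a 2.5-fold lower number from compound 1 to compound 2 (0.40 log units; beyond the scatter) came with 4-methoxyphenyl in place of carboxy at the end of the chain. Compound 3 `O=c1[nH]/c(=N\OCCCc2ccc3ccccc3c2)ccn1[C@@H]1O[C@H](COP(=O)(O)OP(=O)(O)OP(=O)(O)O)[C@@H](O)[C@H]1O` carries the change (naphthalen-2-yl in place of 4-methoxyphenyl on a saturated chain carbon, three bonds along the chain from an oxygen on an unsaturated carbon), so one aromatic ring at that chain end becomes two fused ones and the single acceptor of the methoxy group is lost. For the measured compounds named here, only the step between compound 1 and compound 2 bears on this, and it was modest; it shows an aromatic group at this position is tolerated, but nothing measured speaks to a second fused ring. The step of a 1.4-fold lower number from compound 2 to compound 3 (0.14 log units; within the scatter) is therefore expected to be small, at most slightly toward a lower number, and may well sit within the scatter. Compound 3 is estimated at 200 nM, with a range from 70 nM to 600 nM.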

Compound 3, half-maximal effective concentration: 90 nM
For compound 3 the middle estimate is 2.2-fold (0.35 log units) above the measured one; low and high end bracket the measured number.
By their numbers in this assay, from the lowest: compound 3; then compound 2; then compound 1.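

At this chain end, two fused aromatic rings go beyond what a single ring gave in this assay: a 3.1-fold lower number from compound 2 to compound 3 (0.49 log units; beyond the scatter). The hydrogen-bond acceptor of 4-methoxyphenyl is therefore not needed for a number at this level, and the whole change from carboxy to naphthalen-2-yl amounts to a 7.7-fold lower number from compound 1 to compound 3 (0.89 log units; beyond the scatter), with the three compounds falling in the order carboxy, 4-methoxyphenyl, naphthalen-2-yl and none going against it. No measurement at hand accounts for the gain.

From the compounds shown here alone, compound 3 adds a fused ring and loses the methoxy group in one step, so the share of each stays open; an unsubstituted phenyl group would separate them. Also open, going by these compounds, is whether naphthalen-1-yl, an amine at the chain end or a longer chain would keep this level in this assay.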